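The compounds below may be only part of what the source reports. "The series", "measured", "known", "first", "only" and "open" are said of these compounds alone.

The measured compounds and their values in a functional assay on HL-60 cells (Homo sapiens) for antiproliferative activity; a higher number here means a weaker inhibitor, a lower number a stronger inhibitor:

compound 1, `CCOC(=O)c1ccc(Oc2ccc(OC)cc2)cc1`, a limit of the assay only: > 20000 nM
compound 2, `CCOC(=O)c1ccc(Oc2ccc(OC)c(OC)c2)cc1`, a limit of the assay only: > 20000 nM
compound 3, `COC(=O)c1ccc(Oc2ccc(OC)cc2)c([N+](=O)[O-])c1`, a limit of the assay only: > 20000 nM

None of the three gives a number in this assay; every value shown is a limit, as the limit of > 20000 nM in this assay, at which 3 of the 3 values shown sit, records. From compound 1 to compound 2 the change is methoxy in place of hydrogen on an aromatic carbon, and the step that the two limits leave unreadable from compound 1 to compound 2 is therefore not readable in size. Compound 3 carries a different core; how its core differs from that of compound 1 is not broken down here.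

Compound 4, `COC(=O)c1ccc(Oc2ccc(OC)c(OC)c2)c([N+](=O)[O-])c1`, has not yet been measured. It differs from compound 3 by methoxy in place of hydrogen on an aromatic carbon, the same change as that from compound 1 to compound 2, at the same kind of place. Since compound 1 and compound 2 both sit at the limit (the limit of > 20000 nM in this assay, at which 3 of the 3 values shown sit), that change gave no readable shift, and compound 3 also sits at a limit. Compound 4 is therefore expected to show a step that the limit leaves unreadable from compound 3 to compound 4, that is, essentially none. Compound 4 is estimated at 30000 nM in this assay, most likely reported again only as a limit, between 15000 nM and 80000 nM.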

Compound 4, half-maximal inhibitory concentration: > 20000 nM
Compound 4: a limit, no number; the forecaster's own chance of this, stated with the estimate: 85%; the middle value lies beyond the limit too.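

In this assay, compound 4 also returns only a limit and no number, so the step from compound 3 to compound 4, like that from compound 1 to compound 2, cannot be read in size: the limit of > 20000 nM in this assay, at which 4 of the 4 values shown sit.

The compounds shown leave open how far any of the four lies past that limit, and whether methoxy in place of hydrogen has any effect in this assay at all.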